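This account rests on a few compounds, and the source may have more. Where it says the series, first, only, none or still open, it means among the compounds named here.

Measured so far in an ADME assay on cells (Hepatocyte, Rattus norvegicus) for metabolic stability; on this read-out higher numbers stand for fast clearance and lower numbers for slow clearance:
- compound 1 `CC(C)n1cc(-c2ccnc3[nH]c(C4CCNCC4)cc23)ccc1=O`
- compound 2 `CC(C)n1cc(-c2ccnc3[nH]c(C4CCN(CC(=O)N5CCCC5)CC4)cc23)ccc1=O`: 5.4 uL/min
- compound 3 `CC(C)n1cc(-c2ccnc3[nH]c(C4CCN(CC(=O)N(C)C)CC4)cc23)ccc1=O`: 2.3 uL/min.

The assay reports for compound 1 only a limit, < 1 uL/min. Among the two numbers shown, compound 3 has the lower one; the nearest is compound 2, with a 2.3-fold lower number from compound 2 to compound 3 (0.37 log units; beyond the scatter). Against compound 1 both substituted amines move up: an at least 5.4-fold higher number from compound 1 to compound 2 (0.73 log units; beyond the scatter) and an at least 2.3-fold higher number from compound 1 to compound 3 (0.36 log units; beyond the scatter).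

Compound 4 `CN(C)C(=O)CN1CCC(c2cc3c(-c4ccc(=O)n(C)c4)ccnc3[nH]2)CC1` differs from compound 3 by methyl in place of isopropyl on an aromatic nitrogen. Among the measured compounds shown here, none of the measured steps touches this position; all concern the amine nitrogen in a ring or the carbonyl carbon, so they give no direct precedent. The change is small and the expected step is a 1.3-fold lower number from compound 3 to compound 4 (0.11 log units; within the scatter), within the scatter. Compound 4 is therefore estimated at 1.8 uL/min, with a range of 0.8 uL/min to 4 uL/min.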

Compound 4, intrinsic clearance in a liver preparation (reported as CLH), per the amount of preparation that the assay uses: < 1 uL/min
Compound 4 ended at the assay's limit (the forecaster's own chance of this, stated with the estimate: 20%); at least 1.8-fold (0.25 log units) between middle value and limit.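

Among the compounds shown here, with an at least 2.3-fold lower number from compound 3 to compound 4 (0.36 log units; beyond the scatter) in this assay on going from isopropyl to methyl on the aromatic nitrogen, this position, untouched by the earlier steps, proves to bear on the read-out. The amine nitrogen keeps its (dimethylcarbamoyl)methyl group across this step. The full size of the step cannot be read, because compound 4 sits at a limit of the assay, not at a number: the limit of < 1 uL/min in this assay, at which 2 of the 4 values shown sit.

Open, as far as these compounds go, is how an ethyl group or a longer chain on the aromatic nitrogen would read. Also open, from the compounds shown here alone, is whether methyl gives a similar step with the ((pyrrolidin-1-yl)carbonyl)methyl group of compound 2 on the amine nitrogen.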